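Benzoyloxy to Propyl: One Change Tried on Two Cores

This account rests on a few compounds, and the source may have more. Where it says the series, first, only, none or still open, it means among the compounds named here.

Compound 1, `CN(Cc1cn(CC(O)COC(=O)c2ccccc2)nn1)CC1CCCCC1`, gives 6% in an assay on nucleic acid for inhibition of Nucleic Acid, read by fluorescence, tested at 100 uM; a lower number here means less inhibition, a higher number more inhibition at the concentration tested (going by the name of the read-out).
Compound 2, `CCCCC(O)Cn1cc(CN(C)CC2CCCCC2)nn1`, gives 47% in this assay.
Compound 3, `CCOC(=O)C1CCCN(Cc2cn(CC(O)COC(=O)c3ccccc3)nn2)C1`, gives 6% in this assay.

Compound 1 and compound 2 share a core and differ in a single place: propyl in place of benzoyloxy on a saturated chain carbon, two bonds along the chain from an oxygen on a saturated carbon. That change produced a number 41 percentage points higher from compound 1 to compound 2 (beyond the scatter), a step well beyond the usual scatter. Compound 3 is built on a different core; how the two cores differ is not broken down here. In this assay compound 3 stands level with compound 1, and together they give the lowest numbers of the three, with compound 2 clearly apart from both.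

Compound 4, `CCCCC(O)Cn1cc(CN2CCCC(C(=O)OCC)C2)nn1`, has not yet been measured. It is compound 3 carrying the same change: propyl in place of benzoyloxy on a saturated chain carbon, two bonds along the chain from an oxygen on a saturated carbon. The place is described in identical words for both pairs, so this is the same change on a second core. For the measured compounds named here, with only one earlier instance, the expectation is uncertain, but it rests on that instance. From compound 3 to compound 4 a step of a number 34 percentage points higher from compound 3 to compound 4 (beyond the scatter) is expected. Compound 4 is estimated at 40%, most likely between 15% and 65%.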

Compound 4, a percentage reported as inhibition, at one concentration (the size of the read-out at that concentration, not a potency): 53%
Beside the measured number, compound 4's estimate is 13 percentage points below it, and the stated range covers the measured number.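

On the second core, putting propyl in place of benzoyloxy again raises the read-out in this assay, giving a number 47 percentage points higher from compound 3 to compound 4 (beyond the scatter). Set beside the first case, the two steps cannot be told apart, so across these two cores the change carries over at much the same size: the same change on two cores in this assay, a number 41 percentage points higher (beyond the scatter) from compound 1 to compound 2 and a number 47 percentage points higher (beyond the scatter) from compound 3 to compound 4, 6 percentage points apart, within the scatter of two such steps

This does not show that the change would behave the same way on a further core, and a single read-out at one concentration is not a potency. Nor does it show which part of the swap matters, as the aromatic ring, the double bond and the hydrogen-bond acceptors of benzoyloxy all leave in one move.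

The compounds shown leave open what a plain phenyl, an amine or a longer chain would give in that same place. They also leave open whether a shorter chain than propyl would do as well.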